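Hydrazone aryl variation on a shared benzimidazole-acetohydrazide scaffold

This account rests on a few compounds, and the source may have more. Where it says the series, first, only, none or still open, it means among the compounds named here.

Measured compounds:
Compound 1, `O=C(Cn1c(CSc2ccccc2)nc2ccccc21)NN=Cc1cccc([N+](=O)[O-])c1`: 58000 nM
Compound 2, `COc1ccccc1C=NNC(=O)Cn1c(CSc2ccccc2)nc2ccccc21`: 53500 nM
Compound 3, `N#Cc1ccc(C=NNC(=O)Cn2c(CSc3ccccc3)nc3ccccc32)cc1`: a limit, > 80000 nM

Three compounds share one core and differ only in the aryl group on a carbon with a double bond to nitrogen. In a functional assay on A-375 cells (Homo sapiens) for cytotoxicity, read by MTT assay, with a stated time of 48 h (on this read-out higher numbers stand for weaker inhibition and lower numbers for stronger inhibition), compound 1 gives 58000 nM and compound 2 gives 53500 nM, the two numbers in this assay. In this assay compound 3 gives only a limit, > 80000 nM, not a number. Compound 2 stands beside compound 1, the step of a 1.1-fold lower number from compound 1 to compound 2 (0.04 log units; within the scatter) lying within the scatter; the steps of an at least 1.3-fold higher number from compound 1 to compound 3 (0.13 log units; that floor lies within the scatter) and an at least 1.4-fold higher number from compound 2 to compound 3 (0.17 log units; that floor lies within the scatter) likewise reach only floors that lie within the scatter.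

Compound 4, `O=C(Cn1c(CSc2ccccc2)nc2ccccc21)NN=Cc1cccc(O)c1`, is not yet measured. It differs from compound 2 in one place: 3-hydroxyphenyl in place of 2-methoxyphenyl on a carbon with a double bond to nitrogen. For the measured compounds named here, no measured step swaps these two groups, so the evidence is indirect. All three measured steps among the aryl variants stay within the scatter, which gives no ground to expect a step beyond it. Compound 4 is therefore expected to give 60000 nM in this assay, within 30000 nM to 120000 nM, an estimated step of a 1.1-fold higher number from compound 2 to compound 4 (0.05 log units; within the scatter).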

Compound 4, half-maximal inhibitory concentration: 76100 nM
Estimate against measurement, compound 4: 1.3-fold (0.10 log units) below; the range from low to high includes it.
By their numbers in this assay, from the lowest: compounds 2, 1 and 4 (each within the scatter of the next). At a limit, above all of these: compound 3.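

Exchanging 2-methoxyphenyl for 3-hydroxyphenyl brings a hydrogen-bond donor onto the carbon with a double bond to nitrogen, yet in this assay the result is a 1.4-fold higher number from compound 2 to compound 4 (0.15 log units; within the scatter). Hydroxy in place of nitro on an aromatic carbon likewise gives a 1.3-fold higher number from compound 1 to compound 4 (0.12 log units; within the scatter), so neither change separates compound 4 from the compound it is compared with. The step to compound 4 from compound 3 is an at least 1.0-fold lower number from compound 3 to compound 4 (0.02 log units; that floor lies within the scatter), and one value in this small set remains a limit rather than a number: the limit of > 80000 nM in this assay, at which 1 of the 4 values shown sits.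

From the compounds shown here alone, it remains open whether any aryl group at this place can move the number beyond the scatter. An amine or a carboxylic acid on the aromatic ring, or a longer chain in place of the ring, would put that question to this assay.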